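A few compounds are considered here, and "the series" means these few. Any claim that something is new, unique, unknown or untested is made for them only; others in the source may bear on it.

Working notes on the series. Among the measured compounds shown here, in a functional assay on HeLa cells (Homo sapiens) for antiproliferative activity, read by cell counting, with a stated time of 2 days (on this read-out lower numbers stand for stronger inhibition and higher numbers for weaker inhibition), compound 1 (`COc1ccc(C(=O)c2sc(N3CCCC3)nc2N)cc1OC`) gives 36000 nM, the only true number so far, and it therefore serves as the reference point. Compound 2 (`COc1ccc(C(=O)c2sc(N3CCCC3)nc2N)cc1`) reads > 200000 nM, which is a limit of the assay and not a number. Removing the other methoxy group of compound 1 thus gives an at least 5.5-fold higher number from compound 1 to compound 2 (0.74 log units; beyond the scatter), and this size is a minimum only.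

Compound 3 (`COc1cccc(C(=O)c2sc(N3CCCC3)nc2N)c1`) is the next comparison. Its change from compound 1 is hydrogen in place of methoxy on an aromatic carbon, here ortho to a methoxy group and para to a large group. For the measured compounds named here, the same kind of replacement at a different place is the only measured guide, namely an at least 5.5-fold higher number from compound 1 to compound 2 (0.74 log units; beyond the scatter). Transfer to this place is uncertain, so a step of similar direction but possibly smaller size is expected in this assay, towards weaker inhibition.

The expected step is a 3.1-fold higher number from compound 1 to compound 3 (0.49 log units; beyond the scatter). Compound 3 is estimated at 110000 nM, with an expected range of 45000 nM to 200000 nM.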

Compound 3, half-maximal inhibitory concentration: > 200000 nM
Compound 3: no number, only a limit; the forecaster's own chance of this, stated with the estimate: 35%; middle value at least 1.8-fold (0.25 log units) from the limit.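

In this assay, replacing the methoxy group that sits ortho to a methoxy group and para to a large group with hydrogen gives an at least 5.5-fold higher number from compound 1 to compound 3 (0.74 log units; beyond the scatter), and this size is a minimum only. Compound 3 reads > 200000 nM, which is a limit of the assay and not a number. Each of the two methoxy groups of compound 1 has now been replaced by hydrogen on its own, and the loss of activity is not confined to one place, but an at least 5.5-fold higher number from compound 1 to compound 2 (0.74 log units; beyond the scatter) and the new step cannot be ranked against each other because both end at the same limit: the limit of > 200000 nM in this assay, at which 2 of the 3 values shown sit.

As far as these compounds go, whether a hydroxy group, an ethoxy group or a fluorine atom at this position would keep the activity near that of compound 1, at 36000 nM, stays open. The compounds shown also leave open how far the true values of compound 2 and compound 3 lie beyond the limit, so the full size of both steps cannot be read.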